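The compounds below may be only part of what the source reports. "The series", "measured", "known", "first", "only" and "open" are said of these compounds alone.

Measured compounds:
compound 1: `O=C1C=C(NCc2ccccc2)C(=O)c2c1nc1n2[C@H]2OC[C@@H](O)[C@H]2OC1`, 2670 nM
compound 2: `O=C1C(N2CCCCC2)=CC(=O)c2c1nc1n2[C@H]2OC[C@@H](O)[C@H]2OC1`, > 4000 nM

Of the compounds shown here, two share the same core and have been tested in a functional assay on MGC-803 cells (Homo sapiens) for inhibition, read by sulforhodamine B assay; on this read-out higher numbers stand for weaker inhibition and lower numbers for stronger inhibition. In this assay, among the measured compounds shown here, compound 1 gives 2670 nM, which is the only plain number among the two results. For compound 2 the result is the limit of > 4000 nM in this assay, at which 1 of the 2 values shown sits, a limit of the assay rather than a number. Compound 1 therefore stands as the one measured point from which the next compound can be judged.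

Compound 3, `Cc1ccc(NC2=CC(=O)c3nc4n(c3C2=O)[C@H]2OC[C@@H](O)[C@H]2OC4)cc1C`, has not yet been measured. It differs from compound 1 in one place: 3,4-dimethylphenyl in place of benzyl on an amine nitrogen. For the measured compounds named here, no step between measured compounds is available, so the data give no guide to how swapping a benzyl group for a 3,4-dimethylphenyl group on this amine nitrogen changes inhibition. The expected step of a 1.2-fold lower number from compound 1 to compound 3 (0.08 log units; within the scatter) is a modest one, close to the usual scatter, with the direction left open. Compound 3 is estimated at 2200 nM, with a range from 600 nM to 8000 nM.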

Compound 3, half-maximal inhibitory concentration: 860 nM
Compound 3: middle estimate off by 2.6-fold (0.41 log units), on the high side, within the range that was stated.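

In this assay the amine nitrogen on the shared core now has its first readable step, with 3,4-dimethylphenyl in place of benzyl: a 3.1-fold lower number from compound 1 to compound 3 (0.49 log units; beyond the scatter). So inhibition at this position does respond to what the nitrogen carries, and the change goes towards stronger inhibition. The group that leaves and the group that enters each hold one six-membered aromatic ring of carbon only and no net charge, so a swap that keeps those features the same is still enough to move the number, though nothing measured here bears on why it moves.

As far as these compounds go, this single step replaces the whole group at once, so it stays open how much of the change belongs to the two methyl groups and how much to the rest of the group, a question that a plain phenyl or a 4-methylphenyl on the same nitrogen would help to settle. Also open, from the compounds shown here alone, is how a group of a different kind on this nitrogen, such as a longer chain ending in an amine or a carboxylic acid, would read in this assay.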